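Swapping Hydroxy and Methoxy Positions on One Aryl Ring

This account rests on a few compounds, and the source may have more. Where it says the series, first, only, none or still open, it means among the compounds named here.

Measured compounds:
- Compound 1 `COc1cc(C=C(C(=O)/C=C/c2cccc(OC)c2OC)C(=O)/C=C/c2cccc(OC)c2OC)ccc1O` gives 200 nM in a functional assay on HepG2 cells (Homo sapiens) for antiproliferative activity, read by sulforhodamine B assay, with a stated time of 48 h; on this read-out lower numbers stand for stronger inhibition and higher numbers for weaker inhibition.
- Compound 2 `COc1cc(C=C(C(=O)/C=C/c2cccc(OC)c2OC)C(=O)/C=C/c2cccc(OC)c2OC)cc(OC)c1O` gives 210 nM in this assay.

Compound 1 stands at the lowest of the two numbers in this assay, but its nearest neighbour, compound 2, sits within the scatter: the step of a 1.1-fold higher number from compound 1 to compound 2 (0.02 log units; within the scatter) is too small to count as a real difference.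

Compound 3 `COc1ccc(C=C(C(=O)/C=C/c2cccc(OC)c2OC)C(=O)/C=C/c2cccc(OC)c2OC)cc1O` is not yet measured. The change from compound 1 to compound 3 is 3-hydroxy-4-methoxyphenyl in place of 4-hydroxy-3-methoxyphenyl on a double-bonded chain carbon bound to a double-bonded chain carbon. The same atoms are present in both compounds; only the two oxygen-bearing groups on that aryl ring trade places.

Going by the values given here, no measured step addresses this kind of swap directly. Among the compounds with values here, the only step available, a 1.1-fold higher number from compound 1 to compound 2 (0.02 log units; within the scatter), shows that adding a methoxy on this ring leaves the number in this assay essentially unchanged, which suggests the ring tolerates variation without large shifts. The expected step of a 1.3-fold higher number from compound 1 to compound 3 (0.10 log units; within the scatter) is therefore small, with no clear direction beyond the scatter. The estimate for compound 3 in this assay is 250 nM, with a range from 100 nM to 650 nM.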

Compound 3, half-maximal inhibitory concentration: 270 nM
Compound 3: the middle estimate sits 1.1-fold (0.03 log units) below what was measured, within the range that was stated.
By their numbers in this assay, from the lowest: compounds 1, 2 and 3 (each within the scatter of the next).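

In this assay the swap of 3-hydroxy-4-methoxyphenyl in place of 4-hydroxy-3-methoxyphenyl gives a 1.4-fold higher number from compound 1 to compound 3 (0.13 log units; within the scatter) and so adds something the methoxy step could not show: the same two groups have now been tried in two arrangements on this ring, and the read-out does not tell those arrangements apart. Going by these compounds alone, the step of 3-hydroxy-4-methoxyphenyl in place of 4-hydroxy-3,5-dimethoxyphenyl gives a 1.3-fold higher number from compound 2 to compound 3 (0.11 log units; within the scatter) and thus completes the picture, with all three aryl groups at this place lying within the scatter of one another, so neither the arrangement nor the number of oxygen-bearing groups separates these compounds so far. Nothing available explains why these three rings give such similar numbers.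

On these data alone, all three rings carry only hydroxy and methoxy groups, so it remains open whether this tolerance would hold for a ring with an amine, a carboxylic acid or a longer ethoxy chain in place of these groups, or for a ring with no hydroxy at all. As far as these compounds go, the other two aryl rings are the same in all three compounds, and what a change on them would do also remains open.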